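From benzyl to 3,5-difluorobenzyl in an antiproliferative series

The source may hold more compounds than are shown below. What is called first, only, known or untested is meant among the compounds shown, and "the series" means these compounds.

Going by the values given here, in a functional assay on BAEC cells (Bos taurus) for antiproliferative activity, read by cell counting, with a stated time of 4 days (on this read-out higher numbers stand for weaker inhibition and lower numbers for stronger inhibition), compound 1 `CCOC(=O)CN(Cc1cc(F)cc(F)c1)c1ccc2c(c1)OC(C)(COc1ccc(C#N)cc1)CN2C` gives 25000 nM, the only true number so far. Compound 2 `CN1CC(C)(CO)Oc2cc(N(Cc3ccccc3)C(=O)C(=O)O)ccc21` reads > 100000 nM, which is a limit of the assay and not a number. So compound 2 has no exact position on this scale.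

Compound 3 `CN1CC(C)(CO)Oc2cc(N(Cc3cc(F)cc(F)c3)C(=O)C(=O)O)ccc21` differs from compound 2 in one place: its benzyl becomes 3,5-difluorobenzyl. The counted change is 3,5-difluorophenyl in place of phenyl on a saturated chain carbon bound to an amide-type nitrogen, with 3,5-difluorophenyl in place of phenyl on a saturated chain carbon bound to an amide-type nitrogen.

Among the compounds with values here, no measured pair shows what this change does on its own, so the expectation is loose. In this assay, a small shift toward stronger inhibition is expected at most, quite possibly none beyond the scatter, and compound 3 may well report only a limit too. Compound 1 at 25000 nM is the nearest real number, but it is not a one-place step away from compound 2. The expected change is small, estimated as an at least 1.1-fold lower number from compound 2 to compound 3 (0.04 log units; that floor lies within the scatter). For compound 3, the estimated value is 90000 nM, with an expected range of 30000 nM to 200000 nM.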

Compound 3, half-maximal inhibitory concentration: > 100000 nM
Compound 3 was reported as a limit; the forecaster's own chance of this, stated with the estimate: 65%; at least 1.1-fold (0.04 log units) between middle value and limit.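

Compound 3 reads > 100000 nM, which is a limit of the assay and not a number, so no step can be read from compound 2 to compound 3, because both stop at the same limit: the limit of > 100000 nM in this assay, at which 2 of the 3 values shown sit.

From the compounds shown here alone, whether 3,5-difluorobenzyl in place of benzyl changes inhibition at all stays open.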